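The source may hold more compounds than are shown below. What is called first, only, known or untested is meant among the compounds shown, and "the series" means these compounds.

In a functional assay on HCT-116 cells (Homo sapiens) for inhibition, read by CCK-8 assay, with a stated time of 72 h (on this read-out lower numbers stand for stronger inhibition and higher numbers for weaker inhibition), compound 2 `Nc1ccccc1NC(=O)c1ccc(CNC(=O)c2n[nH]cc2NC(=O)c2ccccc2)cc1` gives 1660 nM. That number lies within the scatter of each of the other two measured compounds. Compound 1 `Nc1ccccc1NC(=O)c1ccc(CNC(=O)c2n[nH]cc2NC(=O)c2ccccc2Cl)cc1` gives 900 nM, and compound 3 `O=C(NO)c1ccc(CNC(=O)c2n[nH]cc2NC(=O)c2ccccc2F)cc1` gives 2200 nM. Compound 4 `Nc1ccccc1NC(=O)c1ccc(CNC(=O)c2n[nH]cc2NC(=O)c2c(F)cccc2F)cc1` has not yet been measured in this assay.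

Compound 4 differs from compound 2 in one place: 2,6-difluorophenyl in place of phenyl on a carbonyl carbon. In words, this is 2,6-difluorophenyl in place of phenyl on a carbonyl carbon. Among the measured compounds shown here, only one measured step changes this same phenyl, and it replaces chloro with hydrogen on an aromatic carbon. For the measured compounds named here, compound 3 also carries fluorine there, but it differs from compound 2 in more than one place and so offers no clean step. Going by the values given here, no measured step shows fluorine alone being added, so the evidence for this change is indirect.

Among the compounds with values here, with a 1.8-fold higher number from compound 1 to compound 2 (0.27 log units; within the scatter) as the only measured step on this phenyl, no shift beyond the scatter is expected for compound 4, only a slight lean toward lower numbers. The estimated change is a 1.4-fold lower number from compound 2 to compound 4 (0.14 log units; within the scatter). For compound 4 the expected value is 1200 nM, with an estimated range of 500 nM to 2800 nM.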

Compound 4, half-maximal inhibitory concentration: 1130 nM
Estimate against measurement, compound 4: 1.1-fold (0.03 log units) above; the range from low to high includes it.
By their numbers in this assay, from the lowest: compounds 1, 4, 2 and 3 (each within the scatter of the next, the first and the last beyond it).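

In this assay, among the compounds shown here, the step of a 1.5-fold lower number from compound 2 to compound 4 (0.17 log units; within the scatter) is the first direct reading of fluorine on this phenyl, and it shows that 2,6-difluorophenyl can replace phenyl on the carbonyl carbon without moving the number beyond the scatter. The step of a 1.3-fold higher number from compound 1 to compound 4 (0.10 log units; within the scatter) adds a comparison between two substituted rings, so phenyl, 2-chlorophenyl and 2,6-difluorophenyl now form a set of three in which each listed step at this position stays within the scatter of this assay and none can be ranked. Nothing measured here explains these small steps or bears on the role of the fluorine atoms.

The compounds shown leave open whether a different group on this carbonyl carbon, such as a pyridine ring, a methoxyphenyl or a simple alkyl chain, would move the number beyond the scatter. They also leave open whether 2,6-difluorophenyl would give an equally small step on the core of compound 3.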